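A few compounds are considered here, and "the series" means these few. Any claim that something is new, unique, unknown or untested is made for them only; others in the source may bear on it.

Measured compounds in an ADME assay on HEK-293T cells (Homo sapiens) for cytotoxicity, read by MTT assay, with a stated time of 24 h; a higher number here means that more compound is tolerated, a lower number that less compound is tolerated:
compound 1 `Cc1ccc(C(=O)n2c(-c3cn(-c4ccccc4)nc3-c3ccc(F)cc3)nc3ccccc32)cc1` gives 178000 nM;
compound 2 `O=C(c1ccncc1)n1c(-c2cn(-c3ccccc3)nc2-c2ccc(F)cc2)nc2ccccc21` gives 151000 nM;
compound 3 `O=C(c1ccncc1)n1c(-c2cn(-c3ccccc3)nc2-c2ccc(C(F)(F)F)cc2)nc2ccccc21` gives 135000 nM.

Compound 2 stands second highest of the three numbers, with compound 3 nearest and compound 1 furthest, both separated from it by steps within the scatter: a 1.2-fold lower number from compound 1 to compound 2 (0.07 log units; within the scatter) and a 1.1-fold lower number from compound 2 to compound 3 (0.05 log units; within the scatter). The three values therefore show no ordering that can be trusted.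

Compound 4 `O=C(c1ccccc1)n1c(-c2cn(-c3ccccc3)nc2-c2ccc(F)cc2)nc2ccccc21` has not yet been measured. It differs from compound 2 in one place: phenyl in place of pyridin-4-yl on a carbonyl carbon. For the measured compounds named here, the step that bears on this change is the one from compound 1 to compound 2, where an aryl group on the same carbonyl carbon was exchanged for pyridin-4-yl and the number moved only within the scatter. The change from compound 2 to compound 4 runs in the opposite direction, pyridin-4-yl giving way to an aryl group without a hetero atom. No step beyond the scatter is expected in this assay.

Compound 4 is accordingly estimated at 160000 nM, with a range from 90000 nM to 280000 nM, which means an expected step of a 1.1-fold higher number from compound 2 to compound 4 (0.03 log units; within the scatter).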

Compound 4, half-maximal cytotoxic concentration: 180000 nM
Compound 4: the middle estimate sits 1.1-fold (0.05 log units) below what was measured; the measured number falls inside the stated range.
By their numbers in this assay, from the lowest: compounds 3, 2, 1 and 4 (each within the scatter of the next).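

Read in this assay the loss of the ring nitrogen, with pyridin-4-yl giving way to phenyl on the carbonyl carbon, gives a 1.2-fold higher number from compound 2 to compound 4 (0.08 log units; within the scatter) and so shows that this exchange has no readable effect when the two groups are compared directly. Hydrogen in place of methyl on the aromatic carbon of that same group gives a 1.0-fold higher number from compound 1 to compound 4 (0.00 log units; within the scatter) and so phenyl, 4-methylphenyl and pyridin-4-yl on this carbonyl carbon all stay within the scatter of one another across compound 1, compound 2 and compound 4. Nothing available explains why these numbers stay so close.

From the compounds shown here alone, it remains open whether an amine, a carboxylic acid or a longer chain on this carbonyl carbon would give a step beyond the scatter. Going by these compounds, all the groups compared here at this place are six-membered aromatic rings, so the tolerance of anything else there is unknown.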